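Shortening the acid chain of an imidazole ether

This account rests on a few compounds, and the source may have more. Where it says the series, first, only, none or still open, it means among the compounds named here.

Compound 1 `CCOC(=O)C(C)(C)CCCCOC(COCc1ccc(OC)cc1)Cn1ccnc1`: 17600 nM in a functional assay on a cell-free system (plasma) for inhibition of Thromboxane-A synthase (Homo sapiens); a lower number here means a stronger inhibitor, a higher number a weaker inhibitor
Compound 2 `COc1ccc(COCC(Cn2ccnc2)OCCCCCCC(C)(C)C(=O)O)cc1`: > 20000 nM in this assay

Compound 2 stands at the edge of what this assay can report (the limit of > 20000 nM in this assay, at which 1 of the 2 values shown sits); its value is a limit of the assay and not a number. Within the data shown here, the only measured step, an at least 1.1-fold higher number from compound 1 to compound 2 (0.05 log units; that floor lies within the scatter), comes from 3-carboxy-3-methylbutyl in place of 1-(ethoxycarbonyl)-1-methylethyl, and since it ends at the limit its full size remains unknown. Compound 3 `COc1ccc(COCC(Cn2ccnc2)OCCC/C=C/C(=O)O)cc1` differs from compound 2 by 2-carboxyethenyl in place of 4-carboxy-4-methylpentyl on a saturated chain carbon, three bonds along the chain from an oxygen on a saturated carbon. Among the measured compounds shown here, no measured step covers this kind of change, and the one step available, an at least 1.1-fold higher number from compound 1 to compound 2 (0.05 log units; that floor lies within the scatter), gives only a floor. The expected step of a number no higher from compound 2 to compound 3 (the limit leaves the size open) is therefore set at none beyond the scatter. Compound 3 is estimated at 20000 nM in this assay, between 5000 nM and 60000 nM, with a fair chance that compound 3 again yields only a limit.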

Compound 3, half-maximal inhibitory concentration: 8330 nM
For compound 3 the middle estimate is 2.4-fold (0.38 log units) above the measured one; the range from low to high includes it.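

Taking 2-carboxyethenyl in place of 4-carboxy-4-methylpentyl gives the first step at this position that clearly exceeds the scatter, an at least 2.4-fold lower number from compound 2 to compound 3 (0.38 log units; beyond the scatter), in this assay. Compound 2 has a limit of the assay and not a number, so this step is only a floor: the limit of > 20000 nM in this assay, at which 1 of the 3 values shown sits. The change to 2-carboxyethenyl in place of 2-(ethoxycarbonyl)-2-methylpropyl, which gives a 2.1-fold lower number from compound 1 to compound 3 (0.32 log units; beyond the scatter), points the same way, making compound 3 the strongest inhibitor of the three.

The shorter chain also carries a double bond and lacks the methyl branching, and the compounds shown do not separate these features. Going by these compounds, how a saturated carboxylic acid chain of the same length or the ethyl ester of the 2-carboxyethenyl chain would compare remains open.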